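Swapping one ring group on a chain carbon

The source may report more compounds than this note shows. Statements on the series, on what has been measured and on what is new or still open speak of the compounds shown alone.

Of the compounds shown here, two have been measured so far in an ADME assay on microsomes from liver (Rattus norvegicus) for metabolic stability, read by LC-MS, with a stated time of 10 min, tested at 0.5 uM (a lower number here means that less of the compound is left, a higher number that more of the compound is left), and they differ in more than one place. Compound 1 `c1ccc2c(c1)CN[C@@H](CN(CC1CCNCC1)[C@H]1CCCc3cccnc31)C2` gives 65% there. Compound 2 `c1cnc2c(c1)CN[C@H](CN(CCCN1CCNCC1)[C@H]1CCCc3cccnc31)C2` gives 87% and so stands as the higher of the two, beyond the usual scatter. Compound 3 `c1cnc2c(c1)CCC[C@@H]2N(CCCN1CCNCC1)Cc1nc2ccccc2s1` has not yet been measured. Its structure departs from compound 2 in one place: a group of 9 heavy atoms (7 carbon, 1 nitrogen, 1 sulfur; one five-membered aromatic ring with 2 hetero atoms, one six-membered aromatic ring of carbon only) in place of a group of 10 heavy atoms (8 carbon, 2 nitrogen; one six-membered non-aromatic ring with 1 hetero atom, one six-membered aromatic ring with 1 hetero atom), on a saturated chain carbon bound to an amine nitrogen and the group that enters is 1,3-benzothiazol-2-yl. Going by the values given here, no measured pair differs in one place only, so the data offer no direct guide to the size of this step. A fall in the percentage remaining is nevertheless expected, estimated as a number 27 percentage points lower from compound 2 to compound 3 (beyond the scatter) and thus beyond the scatter, though this rests on judgement alone. The expected value for compound 3 is 60% with an estimated range of 35% to 82% around it.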

Compound 3, percent of the compound remaining: 21%
Estimate against measurement, compound 3: 39 percentage points above, outside the stated range (below it).
By their numbers in this assay, from the lowest: compound 3; then compound 1; then compound 2.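

Going by these compounds alone, the single change at this place, on a saturated chain carbon bound to an amine nitrogen, is the first to be read on its own, and it shows that the percentage remaining in this assay is highly sensitive to the group held there. Putting 1,3-benzothiazol-2-yl in place of the group that leaves gives a number 66 percentage points lower from compound 2 to compound 3 (beyond the scatter), a large fall, and the exchange also takes the count of hydrogen-bond donors on this group from 1 to 0. Nothing measured here accounts for the fall.

From the compounds shown here alone, it remains open whether a plain phenyl ring, a benzoxazol-2-yl group or a simple open-chain amine at this place would keep more of the compound intact. Within the data shown here, the one step also cannot separate the contribution of the sulfur-containing ring from that of the lost ring nitrogen-hydrogen.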